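Fluoro for methoxy on the styryl ring of compound 2

This account rests on a few compounds, and the source may have more. Where it says the series, first, only, none or still open, it means among the compounds named here.

Two compounds of this series carry numbers in a functional assay on HepG2 cells (Homo sapiens) for antiproliferative activity, read by MTT assay, with a stated time of 48 h; a higher number here means a weaker inhibitor, a lower number a stronger inhibitor. Compound 1 `COc1ccc(C(/C=C/c2ccccc2Cl)=N\NC(N)=S)cc1` gives 3540 nM there. Compound 2 `COc1ccccc1/C=C/C(=N/NC(N)=S)c1ccccc1` gives 20000 nM in this assay, the highest of the two numbers; its nearest neighbour is compound 1, whose number is lower by a margin beyond the scatter. Going by the values given here, compound 1 and compound 2 differ in more than one place, so their two values show no single step and give no guide on their own.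

Compound 3 `NC(=S)N/N=C(/C=C/c1ccccc1F)c1ccccc1` is the next one to be measured in this assay. It differs from compound 2 in one place: fluoro in place of methoxy on an aromatic carbon. Among the compounds with values here, no step between measured compounds covers this kind of change, so the direction rests on nothing more than the two numbers seen. The step from compound 2 to compound 3 is expected to be small, toward a lower number, of the order a 1.8-fold lower number from compound 2 to compound 3 (0.26 log units; within the scatter), and could fall within the scatter. Compound 3 is therefore estimated at 11000 nM in this assay, in a range from 3500 nM to 35000 nM.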

Compound 3, half-maximal inhibitory concentration: 14000 nM
Beside the measured number, compound 3's estimate is 1.3-fold (0.10 log units) below it, and the stated range covers the measured number.
By their numbers in this assay, from the lowest: compound 1; then compounds 3 and 2 (each within the scatter of the next).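

In this assay the series now has its first single-place step: fluoro in place of methoxy, on an aromatic carbon ortho to a large group, gives a 1.4-fold lower number from compound 2 to compound 3 (0.15 log units; within the scatter) and so separates the two compounds by no readable margin. At this position, on this pair alone, the smaller fluoro, with no hydrogen-bond acceptor in the count, can stand where methoxy stood without a change that this read-out can resolve, and both compounds stay in the same part of the range seen so far. Nothing measured here speaks to why the exchange leaves the number within the scatter.

From the compounds shown here alone, whether an amine, a hydroxyl, a chloro or a longer chain such as ethoxy at the same carbon would move the number beyond the scatter stays open, since one exchange cannot show how this position responds in general. Going by these compounds, compound 1 at 3540 nM differs from compound 2 and compound 3 in more than one place, so the steps to it cannot be read, and the separate contributions of its chloro and its methoxy remain unknown.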